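From chloro to methyl on an aromatic ring

The compounds below may be only part of what the source reports. "The series", "measured", "known", "first", "only" and "open" are said of these compounds alone.

For the measured compounds named here, only two compounds with a shared core have numbers so far. In a functional assay on Jurkat cells (Homo sapiens) for inhibition, with a stated time of 24 h (a lower number here means a stronger inhibitor, a higher number a weaker inhibitor), compound 1 `O=[N+]([O-])c1ccccc1Nc1nnc(-c2c[nH]c3ccccc23)o1` gives 30200 nM and compound 2 `Clc1ccc(Nc2nnc(-c3c[nH]c4ccccc34)o2)cc1` gives 30200 nM at the digits shown, so compound 2 stands level with compound 1 and neither can be called the better inhibitor.

The next compound is compound 3 `Cc1ccc(Nc2nnc(-c3c[nH]c4ccccc34)o2)cc1`, which keeps all of compound 2 apart from one group. Going by the values given here, the single change methyl in place of chloro on an aromatic carbon puts methyl in place of chloro on an aromatic carbon, para to a large group, turning 4-chlorophenyl into 4-methylphenyl.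

Among the compounds with values here, no measured pair shows this exchange, so the guide is thin. The group on the aromatic ring differs between compound 1 and compound 2, yet compound 2 at 30200 nM matches compound 1 on the numbers. A step of a 1.0-fold lower number from compound 2 to compound 3 (0.00 log units; within the scatter) is therefore expected to stay within the scatter in this assay with no favoured direction. Compound 3 is estimated at 30000 nM with an expected range of 12000 nM to 60000 nM as the span of likely results.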

Compound 3, half-maximal inhibitory concentration: > 100000 nM
Compound 3 ended at the assay's limit; the forecaster's own chance of this, stated with the estimate: 20%; middle value at least 3.3-fold (0.52 log units) away from the limit.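

At this place on the ring, para to a large group, the choice of group does matter: in this assay, the exchange of chloro for methyl gives an at least 3.3-fold higher number from compound 2 to compound 3 (0.51 log units; beyond the scatter). For the compounds shown here, the two earlier compounds could not show this, as they differ in more than one place and offered no single-change step, so this is the first clear sign that a small change on this ring can weaken inhibition. For compound 3, the reading of > 100000 nM is a limit of the assay and not a number, so the step can be read only as a minimum, and its full size stays unknown: the limit of > 100000 nM in this assay, at which 1 of the 3 values shown sits.

The compounds shown leave open how other groups at this place would read, such as an amine, a methoxy group or a carboxylic acid, and whether any of them would give a lower number than compound 2. They also leave open whether the same exchange of chloro for methyl would have a similar effect elsewhere on the ring, or on a different core.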